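Cyano for isopropyl: expected shift in compound 3

A few compounds are considered here, and "the series" means these few. Any claim that something is new, unique, unknown or untested is made for them only; others in the source may bear on it.

Compound 1 `Cc1ccc(-c2nc(N)c3cc(Cc4ccccc4F)sc3n2)o1` is held in a functional assay on CHO-K1 cells for antagonist activity at adenosine receptor A1 (Homo sapiens), read by a beta-galactosidase reporter and cAMP accumulation, with stated times of 15 min and 6 h (a higher number here means a weaker inhibitor, a lower number a stronger inhibitor), only at a limit of the assay, < 16 nM, which is stated as a limit and not as a number. Within the data shown here, compound 2 `CC(C)c1ccc(-c2nc(N)c3cc(Cc4ccccc4)sc3n2)o1` gives 283 nM in this assay, the only numeric value in the set, and so compound 2 cannot be placed against compound 1 with any order. Compound 3 `N#Cc1ccc(-c2nc(N)c3cc(Cc4ccccc4)sc3n2)o1` differs from compound 2 by cyano in place of isopropyl on an aromatic carbon. Among the measured compounds shown here, no measured pair separates these two groups, so the direction is open. A step beyond the scatter toward a stronger inhibitor from compound 2 to compound 3 is expected, a 2.0-fold lower number from compound 2 to compound 3 (0.31 log units; beyond the scatter), though a change within the scatter cannot be excluded. For compound 3 the estimate is 140 nM, with a range from 40 nM to 500 nM.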

Compound 3, inhibition constant: 3160 nM
Compound 3: middle estimate off by 23-fold (1.35 log units), on the low side, outside the stated range (above it).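

The change from 5-isopropylfuran-2-yl to 5-cyanofuran-2-yl in this assay reads as an 11-fold higher number from compound 2 to compound 3 (1.05 log units; beyond the scatter) and so moves toward a weaker inhibitor. Among these compounds, this is the first measured pair, and it shows that the group on this aromatic carbon next to the ring oxygen can shift the read-out well beyond the scatter, with cyano the poorer of the two groups here. Nothing at hand bears on why the step is this large.

On these data alone, whether the loss comes from cyano itself or from the absence of isopropyl stays open, and an amine, a carboxylic acid or a longer alkyl chain at this place would help separate the two. Compound 1 stands at < 16 nM which is a limit, and steps to it cannot be read.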